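Thiophen-2-yl in place of 4-fluorophenyl: working notes

This account rests on a few compounds, and the source may have more. Where it says the series, first, only, none or still open, it means among the compounds named here.

In a functional assay on MDA-MB-231 cells (Homo sapiens) for inhibition, read by MTT assay, with a stated time of 72 h (a lower number here means a stronger inhibitor, a higher number a weaker inhibitor), compound 1 `O=C(NO)c1ccc(CNCc2nc(-c3ccc(Cl)cc3)no2)cc1` gives 10900 nM and compound 2 `O=C(NO)c1ccc(CNCc2nc(-c3ccc(F)cc3)no2)cc1` gives 9120 nM. These two values lie within the scatter of each other, so compound 2 cannot be separated from compound 1 on the numbers available.

The next compound, compound 3 `O=C(NO)c1ccc(CNCc2nc(-c3cccs3)no2)cc1`, carries thiophen-2-yl in place of 4-fluorophenyl on an aromatic carbon. The new group sits on a five-membered aromatic ring with 2 nitrogen and 1 oxygen.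

Among the measured compounds shown here, only one measured step bears on this change: a 1.2-fold lower number from compound 1 to compound 2 (0.08 log units; within the scatter), with fluoro in place of chloro, is within the scatter. That step exchanges a single substituent, whereas the change to compound 3 replaces the whole aromatic ring, so the support is indirect. For the measured compounds named here, no measured compound shows the effect of such a replacement. No shift beyond the scatter is therefore expected in this assay, and no direction is favoured, though the range is kept wide.

The expected change is a 1.1-fold higher number from compound 2 to compound 3 (0.04 log units; within the scatter). For compound 3 the estimated value is 10000 nM, with an expected range of 4500 nM to 22000 nM.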

Compound 3, half-maximal inhibitory concentration: 23900 nM
For compound 3 the middle estimate is 2.4-fold (0.38 log units) below the measured one; the measured number lies above the stated range.
By their numbers in this assay, from the lowest: compounds 2 and 1 (each within the scatter of the next); then compound 3.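

In this assay the place on the five-membered aromatic ring with 2 nitrogen and 1 oxygen responds to replacement of the whole aromatic ring: thiophen-2-yl in place of 4-fluorophenyl gives a 2.6-fold higher number from compound 2 to compound 3 (0.42 log units; beyond the scatter) and thiophen-2-yl in place of 4-chlorophenyl gives a 2.2-fold higher number from compound 1 to compound 3 (0.34 log units; beyond the scatter) as a second modest step beyond the scatter. The exchange of chloro for fluoro had shown no shift beyond the scatter, so these are the first steps in the series to show that a change at this place can separate compounds, and both run towards a higher number. Nothing measured on hand accounts for these steps.

The compounds shown leave open whether the steps belong to the smaller ring or to the sulfur atom, a question that unsubstituted phenyl or furan-2-yl at the same place would address. From the compounds shown here alone, all three values also come from this assay alone, and whether the same order holds in other cell lines stays open.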